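The source may hold more compounds than are shown below. What is called first, only, known or untested is meant among the compounds shown, and "the series" means these compounds.

Values in a functional assay on the whole organism for antagonist activity, with Mus musculus as the target; on this read-out lower numbers stand for an effect already at smaller amounts and higher numbers for an effect only at larger amounts of compound:

- Compound 1 `CC1CCC(=O)N1CC#CCN(C)C`: > 100 mg/kg, a limit.
- Compound 2 `COC(=O)N(C)C(C)C#CCn1cncc1C`: 3.7 mg/kg.
- Compound 3 `O=C1OCCN1CC#CCn1ccnc1`: > 100 mg/kg, a limit.
- Compound 4 `Cc1cncn1CC#CCN1CCOC1=O`: not yet measured.

Compound 3 stands at > 100 mg/kg, which is a limit and not a number. Within the data shown here, the series so far shows (the limit of > 100 mg/kg in this assay, at which 2 of the 3 values shown sit). Compound 2 is the only one of the three with a number.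

Going to compound 4 places methyl in place of hydrogen on an aromatic carbon of the five-membered aromatic ring with 2 nitrogen: methyl in place of hydrogen on an aromatic carbon. Among the measured compounds shown here, no two measured compounds differ in one place only, so no measured step gives the size of this change directly. For the measured compounds named here, the only guide is compound 2, which carries the same methyl-bearing ring and gives 3.7 mg/kg, though it also differs from compound 4 elsewhere. On that single value, a step towards smaller doses is expected, well beyond the usual scatter but of uncertain size. The expected change is an at least 4.0-fold lower number from compound 3 to compound 4 (0.60 log units; beyond the scatter). A result that is again only a limit remains quite possible. For compound 4 the estimated value is 25 mg/kg, with an expected range from 4 mg/kg to 100 mg/kg.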

Compound 4, dose for half-maximal effect: 37 mg/kg
Estimate against measurement, compound 4: 1.5-fold (0.17 log units) below; measured number inside the range.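

In this assay, methyl in place of hydrogen on an aromatic carbon of the five-membered aromatic ring with 2 nitrogen now has a direct reading: an at least 2.7-fold lower number from compound 3 to compound 4 (0.43 log units; beyond the scatter). Among these compounds, this is the first pair that differs in one place only, and it shows that this carbon, next to the ring atom that bears a large group, is a place where one added methyl brings the read-out from a limit to a number. The size of the change remains a lower bound, because compound 3 sits at a limit and not at a number: the limit of > 100 mg/kg in this assay, at which 2 of the 4 values shown sit.

The compounds shown leave open whether ethyl, a chlorine atom or an amine on this carbon would act as methyl does, and whether methyl on another aromatic carbon of the ring would give a similar step. Compound 2 gives 3.7 mg/kg but differs from compound 4 in more than one place, so the part played by the rest of the molecule, away from this ring, cannot be read from this pair.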